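Methyl on an Oxygen: What to Expect for Activation

The source may hold more compounds than are shown below. What is called first, only, known or untested is meant among the compounds shown, and "the series" means these compounds.

Compound 1 `COCCCN1C(/C=C/c2ccc(O)cc2)=CC(=O)CC1c1ccc(O)cc1` gives 97.8% in an ADME assay on CHO-K1 cells (Cricetulus griseus) for activation, read by fluorescence, tested at 1 uM; a lower number here means a stronger effect, a higher number a weaker effect of the compound at the concentration tested.
Compound 2 `O=C(/C=C(/C=C/c1ccc(O)cc1)NCCCO)/C=C/c1ccc(O)cc1` gives 86.4% in this assay.

Compound 2 has the lower of the two numbers in this assay, and its gap to compound 1 lies beyond the usual scatter. Compound 3 `COCCCNC(=C\C(=O)/C=C/c1ccc(O)cc1)/C=C/c1ccc(O)cc1` keeps the core of compound 2 and differs in one place: methyl in place of hydrogen on an oxygen on a saturated carbon. No measured pair differs in only this place, and compound 1 and compound 2 differ in more than this, so the size of the step is not yet shown. In this assay a small step, expected to stay within the scatter, is estimated: a number 3.6 percentage points higher from compound 2 to compound 3 (within the scatter). Compound 3 is therefore expected near 90%, within 78% to 100%.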

Compound 3, a percentage reported as activity, at one concentration (the size of the read-out at that concentration, not a potency): 99.8%
For compound 3 the middle estimate is 9.8 percentage points below the measured one, within the range that was stated.
By their numbers in this assay, from the lowest: compound 2; then compounds 1 and 3 (each within the scatter of the next).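

In this assay the change from hydroxy to methoxy brings a number 13.4 percentage points higher from compound 2 to compound 3 (beyond the scatter) and so gives a weaker effect at the concentration tested. Among the compounds shown here, this is the first pair differing only in this place, which shows that a single methyl on this oxygen is enough to move the number. Nothing available explains the step.

This single pair cannot show whether the same step would appear on another core. On these data alone, whether an amine in place of the hydroxy, or an ethyl on this oxygen, would keep the lower number also remains open.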